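The source may hold more compounds than are shown below. What is called first, only, known or untested is meant among the compounds shown, and "the series" means these compounds.

Measured in a functional assay on A549 cells (Homo sapiens) for antiproliferative activity, read by MTT assay, with a stated time of 72 h; a higher number here means a weaker inhibitor, a lower number a stronger inhibitor:
- compound 1 `COc1ccccc1-c1ccc2ncn(-c3cc(OC)c(OC)c(OC)c3)c2c1`: 4320 nM
- compound 2 `COc1ccc(-c2ccc3ncn(-c4cc(OC)c(OC)c(OC)c4)c3c2)cc1O`: 200 nM
- compound 3 `COc1ccc(-c2ccc3ncn(-c4cc(OC)c(OC)c(OC)c4)c3c2)cc1F`: 1430 nM

Compound 2, at 200 nM, has the lowest number of the three and is the strongest inhibitor here. Compound 4 `COc1cc(-n2cnc3ccc(-c4cccc(O)c4)cc32)cc(OC)c1OC` keeps its hydroxy group but loses the methoxy: hydrogen in place of methoxy on an aromatic carbon. This is hydrogen in place of methoxy on an aromatic carbon, turning 3-hydroxy-4-methoxyphenyl into 3-hydroxyphenyl.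

For the measured compounds named here, no measured step makes this exact change, so the evidence is indirect. Exchanging only the hydroxy for fluoro gave a 7.2-fold higher number from compound 2 to compound 3 (0.85 log units; beyond the scatter). Going from 2-methoxyphenyl to the group in compound 2 gave a 22-fold lower number from compound 1 to compound 2 (1.33 log units; beyond the scatter), while the fluoro version gave a smaller 3.0-fold lower number from compound 1 to compound 3 (0.48 log units; beyond the scatter). Changes on this ring therefore shift this assay well beyond the scatter, and both other groups tested give higher numbers than compound 2. A modest rise is expected here, though the data cannot confirm its direction. The expected change is a 6.0-fold higher number from compound 2 to compound 4 (0.78 log units; beyond the scatter). Compound 4 is estimated at 1200 nM, within an expected range of 300 nM to 5000 nM.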

Compound 4, half-maximal inhibitory concentration: 250 nM
Estimate against measurement, compound 4: 4.8-fold (0.68 log units) above, and the stated range ends above it.
By their numbers in this assay, from the lowest: compounds 2 and 4 (each within the scatter of the next); then compound 3; then compound 1.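

In this assay, taking the methoxy group off the 3-hydroxy-4-methoxyphenyl group changes little, with a 1.3-fold higher number from compound 2 to compound 4 (0.10 log units; within the scatter), so at this position the methoxy group is not needed for the activity seen here. The 3-hydroxyphenyl group also compares well with the other two groups, with a 5.7-fold lower number from compound 3 to compound 4 (0.76 log units; beyond the scatter) and a 17-fold lower number from compound 1 to compound 4 (1.24 log units; beyond the scatter), and among these four compounds the two carrying a hydroxy group, compound 2 and compound 4, have the lower numbers, with no compound going against this. No measurement shown explains why the methoxy group can be lost so freely.

Going by these compounds, whether an amine or a carboxylic acid could stand in place of the hydroxy group and keep the number this low remains open. So does whether an ethoxy group would be tolerated where the methoxy group sat.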